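Swapping 3,4-dimethylphenyl for 2,5-dichlorophenyl on a carbonyl carbon

This account rests on a few compounds, and the source may have more. Where it says the series, first, only, none or still open, it means among the compounds named here.

In a functional assay on C8166 cells (Homo sapiens) for cytotoxicity, read by MTT assay (a lower number here means that less compound is tolerated, a higher number that more compound is tolerated), compound 1 `Cc1cc(S(N)(=O)=O)ccc1NC(=O)COc1ccc(Cl)cc1NC(=O)c1ccccc1` gives 207000 nM. Compound 2 `Cc1ccc(C)c(C(=O)Nc2cc(Cl)ccc2OCC(=O)Nc2ccc(S(N)(=O)=O)cc2C)c1` gives 79700 nM. Compound 3 `Cc1ccc(C(=O)Nc2cc(Cl)ccc2OCC(=O)Nc2ccc(S(N)(=O)=O)cc2C)cc1C` gives 84100 nM, which places it level with compound 2 within the scatter and clearly under compound 1.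

Compound 4 `Cc1cc(S(N)(=O)=O)ccc1NC(=O)COc1ccc(Cl)cc1NC(=O)c1cc(Cl)ccc1Cl` has yet to be measured. It carries 2,5-dichlorophenyl in place of 3,4-dimethylphenyl on a carbonyl carbon.

Among the measured compounds shown here, three measured steps bear on this change. Replacing phenyl with a dimethylphenyl group gave modest shifts, a 2.6-fold lower number from compound 1 to compound 2 (0.41 log units; beyond the scatter) and a 2.5-fold lower number from compound 1 to compound 3 (0.39 log units; beyond the scatter). Exchanging one dimethylphenyl group for the other gave only a 1.1-fold higher number from compound 2 to compound 3 (0.02 log units; within the scatter). For the measured compounds named here, no measured compound carries a dichlorophenyl group at this place, so the comparison is indirect. Going by the values given here, the closest precedent is compound 2 at 79700 nM. No shift beyond the scatter is therefore expected in this assay, and the estimate is a 1.1-fold lower number from compound 3 to compound 4 (0.02 log units; within the scatter). For compound 4 the expected value is 80000 nM, with an estimated range of 35000 nM to 180000 nM.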

Compound 4, half-maximal cytotoxic concentration: 42100 nM
For compound 4 the middle estimate is 1.9-fold (0.28 log units) above the measured one, within the range that was stated.
By their numbers in this assay, from the lowest: compounds 4, 2 and 3 (each within the scatter of the next); then compound 1.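

In this assay the 2,5-dichlorophenyl group on this carbonyl carbon stays level with both dimethylphenyl groups, with a 2.0-fold lower number from compound 3 to compound 4 (0.30 log units; within the scatter) and a 1.9-fold lower number from compound 2 to compound 4 (0.28 log units; within the scatter) as the two steps. Among the compounds shown here, measured against the unsubstituted phenyl group, the same ring gives a 4.9-fold lower number from compound 1 to compound 4 (0.69 log units; beyond the scatter) and this is the largest step seen at this position so far. The place therefore accepts chlorine atoms on the ring as well as methyl groups without a shift beyond the scatter, and all three substituted rings, in compounds 2, 3 and 4, sit under compound 1.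

On these data alone, whether a ring carrying one chlorine atom, a methoxy group or an amine would stay at the same level remains open. Nothing at hand gives a reason for the step from the phenyl group to the substituted rings.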